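The source may report more compounds than this note shows. Statements on the series, on what has been measured and on what is new or still open speak of the compounds shown alone.

Measured so far:
compound 1, `Cc1ccccc1-c1oc2ccccc2c(=O)c1C`, 156 ug/mL;
compound 2, `Cc1cccc(-c2oc3ccccc3c(=O)c2C)c1`, 250 ug/mL;
compound 3, `COc1ccccc1-c1oc2ccccc2c(=O)c1C`, 143 ug/mL.

All three were tested in a functional assay, read by spectrophotometry, with a stated time of 20 min; on this read-out lower numbers stand for stronger inhibition and higher numbers for weaker inhibition. The three numbers do not separate from one another beyond the usual scatter of this kind of measurement, so none of the three can be called stronger or weaker than the others. Compound 2 is built from the same atoms as compound 1, joined differently; the difference between the two cores is not broken down here.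

Compound 3 arises from compound 1 by one change, (methoxy in place of methyl on an aromatic carbon), and the step it made in this assay was a 1.1-fold lower number from compound 1 to compound 3 (0.04 log units; within the scatter).

Compound 4, `COc1cccc(-c2oc3ccccc3c(=O)c2C)c1`, has not been measured yet. It arises from compound 2 by methoxy in place of methyl on an aromatic carbon. For the measured compounds named here, this is the same kind of change as the one from compound 1 to compound 3, but not the same: in compound 3 the group sits ortho to a large group, in compound 4 it sits meta to a large group.

Going by the values given here, since the one measured example of this change, from compound 1 to compound 3, moved the number only within the scatter, the step from compound 2 to compound 4 in this assay is expected to be small as well, about a 1.1-fold lower number from compound 2 to compound 4 (0.04 log units; within the scatter), with the different placement of the group leaving room for some deviation. On that basis compound 4 is estimated at 230 ug/mL, likely between 120 ug/mL and 450 ug/mL.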

Compound 4, half-maximal inhibitory concentration: 156 ug/mL
Compound 4: middle estimate off by 1.5-fold (0.17 log units), on the high side; the range from low to high includes it.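

The swap of methyl for methoxy, tested in this assay on a second core, gave a 1.6-fold lower number from compound 2 to compound 4 (0.20 log units; within the scatter) and so stayed inside the usual scatter, as it did on the core of compound 1. Set side by side, the two steps cannot be told apart, so in these two cases the change carries over from one core to the other without a visible difference: the same change on two cores in this assay, a 1.1-fold lower number (0.04 log units; within the scatter) from compound 1 to compound 3 and a 1.6-fold lower number (0.20 log units; within the scatter) from compound 2 to compound 4, 1.5-fold (0.17 log units) apart, within the scatter of two such steps. This does not show that the swap is without any effect or that the placement of the group never matters, for a small real difference could stay hidden inside the scatter, and two pairs, with the group placed differently in each, are too few to support a rule for the wider series.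

The compounds shown leave open whether another group in these places, such as an amine, a carboxylic acid or a longer chain like ethoxy, would separate from methyl and methoxy in this assay by more than the scatter. They also leave open whether methoxy in place of methyl would behave the same way on a core changed elsewhere in the molecule.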